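Compound 3 to compound 4: nitro in place of methoxy

The source may hold more compounds than are shown below. What is called first, only, known or untested is meant among the compounds shown, and "the series" means these compounds.

Compound 1 `N#C/C(=C\c1ccccc1OS(=O)(=O)c1ccc([N+](=O)[O-])cc1)C(=O)Nc1nnc(-c2cccs2)s1`: 33%
Compound 2 `COc1ccc(Cc2nnc(NC(=O)/C(C#N)=C/c3ccccc3OS(=O)(=O)c3ccc([N+](=O)[O-])cc3)s2)cc1`: 17%
Compound 3 `COc1ccc(S(=O)(=O)Oc2ccccc2/C=C(\C#N)C(=O)Nc2nnc(Cc3ccc(C)cc3)s2)cc1`: 28%

In an ADME assay on HEK-293T cells (Homo sapiens) for inhibition, read by CCK-8 assay, with a stated time of 48 h, tested at 20 uM (a higher number here means more inhibition of growth at the concentration tested, a lower number less inhibition of growth), compound 3 reads 28% and sits within the usual scatter of compound 1 (33%), while compound 2 (17%) lies lower, beyond that scatter.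

Compound 4 `Cc1ccc(Cc2nnc(NC(=O)/C(C#N)=C/c3ccccc3OS(=O)(=O)c3ccc([N+](=O)[O-])cc3)s2)cc1` differs from compound 3 by nitro in place of methoxy on an aromatic carbon. Within the data shown here, no measured step covers this exchange. Among the measured compounds shown here, the only step available is a number 16 percentage points lower from compound 1 to compound 2 (beyond the scatter), which is a different change, 4-methoxybenzyl in place of thiophen-2-yl on an aromatic carbon. It bears on the question only indirectly, as a guide to how far one change has moved the number in this series.

Compound 4 shares the 4-nitrophenyl group with compound 1 (33%) and compound 2 (17%), and these two values lie on either side of the value of compound 3 (28%). They therefore suggest no clear direction. The estimated result is a number 4 percentage points lower from compound 3 to compound 4 (within the scatter), and no step beyond the scatter is expected. For compound 4 the expected value is 24%, with an estimated range from 11% to 37%.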

Compound 4, percent growth inhibition at one concentration: 9%
The estimate for compound 4 lay 15 percentage points above the measured number, and the stated range ends above it.
By their numbers in this assay, from the lowest: compounds 4 and 2 (each within the scatter of the next); then compounds 3 and 1 (each within the scatter of the next).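

In this assay, among these compounds, the exchange of (4-methoxyphenyl)sulfonyl for (4-nitrophenyl)sulfonyl gives a number 19 percentage points lower from compound 3 to compound 4 (beyond the scatter), which shows for the first time in this set that the group para to a large group on this aromatic ring can move the number beyond the scatter. With the 4-nitrophenyl group held constant, methyl in place of methoxy on the benzyl ring gives a number 8 percentage points lower from compound 2 to compound 4 (within the scatter), so this pair shows no separation beyond the scatter, whereas 4-methylbenzyl in place of thiophen-2-yl gives a number 24 percentage points lower from compound 1 to compound 4 (beyond the scatter), which joins the earlier step with 4-methoxybenzyl in showing a lower number for a benzyl group at that place. The compounds come with no measurement that would account for any of these steps.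

From the compounds shown here alone, the nitro and methoxy exchange has been read only with the 4-methylbenzyl group on the core, so it remains open whether it would hold with thiophen-2-yl or 4-methoxybenzyl there. Going by these compounds, it is also open where an amine or a carboxylic acid would fall at the position now held by nitro or methoxy.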